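The compounds below may be only part of what the source reports. "The series", "measured", "known", "first", "only" and "open" are said of these compounds alone.

In a functional assay on HEK293 cells for agonist activity at D(4) dopamine receptor (Homo sapiens), read by FLIPR (on this read-out lower numbers stand for smaller maximal responses and higher numbers for larger maximal responses), the three measured compounds gave these values:

Compound 1, `O=C(NCN1CCC(c2cccc[n+]2[O-])CC1)c1ccccc1`, gives 63%.
Compound 2, `O=C(NCN1CCC(c2cccc[n+]2[O-])CC1)c1ccc(F)c(Cl)c1`, gives 67%.
Compound 3, `Cc1cc(C)cc(C(=O)NCN2CCC(c3cccc[n+]3[O-])CC2)c1`, gives 56%.

Compound 3 has the lowest of these three numbers. Its nearest neighbour is compound 1, and that gap, a number 7 percentage points lower from compound 1 to compound 3 (within the scatter), lies within the usual scatter of this assay, so the two cannot really be told apart. The gap to compound 2, a number 11 percentage points lower from compound 2 to compound 3 (beyond the scatter), is a little wider and does fall beyond the scatter, though it remains modest.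

Compound 4, `Cc1ccc(C(=O)NCN2CCC(c3cccc[n+]3[O-])CC2)cc1C`, is reached from compound 3 by a single change: 3,4-dimethylphenyl in place of 3,5-dimethylphenyl on a carbonyl carbon. Both measured steps that lead into compound 3 also swap one aromatic group on the carbonyl carbon for another, and both are small: a number 7 percentage points lower from compound 1 to compound 3 (within the scatter) and a number 11 percentage points lower from compound 2 to compound 3 (beyond the scatter). Going by the values given here, neither of them moves two methyl groups to different places on the same ring, so there is no direct precedent for this exact change. Among the compounds with values here, since every swap at this position so far has stayed small, the expected step in this assay is a number 4 percentage points higher from compound 3 to compound 4 (within the scatter), most likely not beyond the scatter in either direction. Compound 4 is therefore estimated at 60%, with a range from 48% to 72%.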

Compound 4, largest response reached (reported as efficacy), in percent of the reference or control that the assay uses: 65%
Beside the measured number, compound 4's estimate is 5 percentage points below it; the measured number falls inside the stated range.
By their numbers in this assay, from the lowest: compounds 3, 1, 4 and 2 (each within the scatter of the next, the first and the last beyond it).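

Shifting one methyl group on the ring, with the atoms unchanged, gives a number 9 percentage points higher from compound 3 to compound 4 (within the scatter) in this assay, so even this rearrangement of the same atoms on the carbonyl carbon's aryl group stays inside the usual scatter. The other two comparisons, a number 2 percentage points higher from compound 1 to compound 4 (within the scatter) and a number 2 percentage points lower from compound 2 to compound 4 (within the scatter), are also within the scatter, so compound 4 cannot be told apart from any of the other three compounds, and the 3,4-dimethylphenyl group sits level with phenyl and 3-chloro-4-fluorophenyl. Among the four compounds, the only step beyond the scatter remains a number 11 percentage points lower from compound 2 to compound 3 (beyond the scatter), which involves the 3,5-dimethylphenyl group, and nothing presented here explains that modest gap or the small differences around it.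

All four compounds carry a substituted or plain phenyl group on the carbonyl carbon, so this series says nothing yet about how a saturated cyclohexyl group, a longer chain or a phenyl ring bearing an amine or a carboxylic acid would behave there. The figures also report only the largest response reached, which leaves open how much of each compound is needed to produce that response.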